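Fluoro for methoxy on a weakly cytotoxic indole series

A few compounds are considered here, and "the series" means these few. Any claim that something is new, unique, unknown or untested is made for them only; others in the source may bear on it.

Measured compounds:
compound 1 `N#C/C(=C\c1c[nH]c2cc(F)ccc12)C(=O)c1c[nH]c2ccccc12` — 31600 nM
compound 2 `COc1ccc2c(/C=C(\C#N)C(=O)c3c[nH]c4ccccc34)c[nH]c2c1` — > 50000 nM
compound 3 `COc1ccc(Cn2cc(/C=C(\C#N)C(=O)c3c[nH]c4cc(OC)ccc34)c3ccccc32)cc1` — > 50000 nM

Three compounds were tested in a functional assay on MIA PaCa-2 cells (Homo sapiens) for cytotoxicity, read by WST assay, with a stated time of 48 h; a lower number here means a stronger inhibitor, a higher number a weaker inhibitor. Compound 1 `N#C/C(=C\c1c[nH]c2cc(F)ccc12)C(=O)c1c[nH]c2ccccc12` gives 31600 nM in this assay. For compound 2 `COc1ccc2c(/C=C(\C#N)C(=O)c3c[nH]c4ccccc34)c[nH]c2c1` the assay reports only a limit, > 50000 nM. For compound 3 `COc1ccc(Cn2cc(/C=C(\C#N)C(=O)c3c[nH]c4cc(OC)ccc34)c3ccccc32)cc1` the assay likewise reports only a limit, > 50000 nM.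

Compound 1 and compound 2 differ in one place, (fluoro in place of methoxy on an aromatic carbon), and this change produced an at least 1.5-fold lower number from compound 2 to compound 1 (0.19 log units; that floor lies within the scatter). How the core of compound 3 differs from the core of compound 2 is not broken down here.

Compound 4 `COc1ccc(Cn2cc(/C=C(\C#N)C(=O)c3c[nH]c4cc(F)ccc34)c3ccccc32)cc1` has not yet been measured in this assay. It stands to compound 3 as compound 1 stands to compound 2: the change is fluoro in place of methoxy on an aromatic carbon, the same change, at the same place. Since compound 3 sits at a limit, the expectation for compound 4 rests on the step from compound 2 to compound 1 and on (the limit of > 50000 nM in this assay, at which 2 of the 3 values shown sit), which leaves it open whether a number will appear at all. Among the compounds with values here, the step expected is an at least 1.1-fold lower number from compound 3 to compound 4 (0.04 log units; that floor lies within the scatter), in line with the one measured step. Compound 4 is therefore estimated at 45000 nM in this assay, with a range from 18000 nM to 110000 nM.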

Compound 4, half-maximal inhibitory concentration: 29400 nM
Estimate against measurement, compound 4: 1.5-fold (0.18 log units) above, within the range that was stated.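

In this assay, fluoro in place of methoxy on the core of the second pair gives an at least 1.7-fold lower number from compound 3 to compound 4 (0.23 log units; that floor lies within the scatter). Set beside the first pair, the change has now been examined on two cores, and in each pair the fluoro compound has a measured number while its methoxy partner stands only at a limit of the assay: the same change on two cores in this assay, an at least 1.5-fold lower number (0.19 log units; that floor lies within the scatter) from compound 2 to compound 1 and an at least 1.7-fold lower number (0.23 log units; that floor lies within the scatter) from compound 3 to compound 4; the limit leaves it open whether they differ. This does not fix the size of the change on either core, nor does it show that the size carries over unchanged from one core to the other, since each step rests on a limit and reaches only a floor within the usual scatter of the assay: the limit of > 50000 nM in this assay, at which 2 of the 4 values shown sit.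

The compounds shown leave open whether a group other than fluoro or methoxy at this place, such as chloro, an amine or a carboxylic acid, would give a measured number in this assay, and how such a group would compare with fluoro on the two cores. They also leave open whether the same change would carry over to a core bearing a different group on the ring nitrogen, such as a longer alkyl chain in place of the substituted benzyl group of compound 3 and compound 4.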